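The source may hold more compounds than are shown below. What is called first, only, known or untested is meant among the compounds shown, and "the series" means these compounds.

Compound 1, `Cc1cc(NC(=O)Nc2ccc(O)cc2)c2ccccc2n1`, and compound 2, `COC(=O)c1cccc(NC(=O)Nc2cc(C)nc3ccccc23)c1`, share a core and differ only in the group on the terminal aromatic ring of the urea. In an ADME assay on HepG2 cells (Homo sapiens) for cytotoxicity, with a stated time of 72 h (on this read-out higher numbers stand for an effect only at larger amounts of compound and lower numbers for an effect already at smaller amounts), compound 1 reaches only the limit of the assay, reported as > 25000 nM, and not a number. Compound 2 gives 23000 nM in this assay. Within the data shown here, compound 2 therefore stands as the only compound with a measured number in this assay, the other value being (the limit of > 25000 nM in this assay, at which 1 of the 2 values shown sits).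

Compound 3, `Cc1cc(NC(=O)Nc2cccc(Cl)c2)c2ccccc2n1`, is not yet measured. It differs from compound 2 by chloro in place of methoxycarbonyl on an aromatic carbon. Among the measured compounds shown here, no step between measured compounds is available to guide this change, so there is nothing on which to rest a direction; the author expects the step from compound 2 to compound 3 to stay within the usual scatter, an estimated 1.2-fold lower number from compound 2 to compound 3 (0.06 log units; within the scatter), with no clear direction. Accordingly, compound 3 is expected to give about 20000 nM in this assay, with a likely range from 8000 nM to 50000 nM, and there is a fair chance that it too is reported only as a limit.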

Compound 3, half-maximal effective concentration: 19000 nM
Compound 3: the middle estimate sits 1.1-fold (0.02 log units) above what was measured, and the stated range covers the measured number.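

In this assay, among these compounds, chloro in place of methoxycarbonyl on an aromatic carbon, meta to a large group, gives a 1.2-fold lower number from compound 2 to compound 3 (0.08 log units; within the scatter), the first step between two measured numbers. At this place, then, a chloro group with no hydrogen-bond acceptors and a methoxycarbonyl group with its double bond and two acceptors do not separate the two compounds beyond the scatter, although only this one exchange is shown. The other comparison, 3-chlorophenyl in place of 4-hydroxyphenyl on an amide-type nitrogen, gives an at least 1.3-fold lower number from compound 1 to compound 3 (0.11 log units; that floor lies within the scatter), and this is only a floor, because one of its two ends is not a number but a limit: the limit of > 25000 nM in this assay, at which 1 of the 3 values shown sits.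

The compounds shown leave open whether an amine, a carboxylic acid or a longer chain at this place on the terminal ring would move the number beyond the scatter. They also leave open how far the true step to the 4-hydroxyphenyl compound lies beyond its floor, and whether any change on the shared core would matter more than changes on the terminal ring.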